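A few compounds are considered here, and "the series" means these few. Any claim that something is new, unique, unknown or untested is made for them only; others in the source may bear on it.

Three measured compounds:
compound 1, `Cn1cc(-c2cnc3[nH]cc(-c4ccc(C#N)cc4)c3c2)cn1`, 2000 nM;
compound 2, `Cn1cc(-c2cnc3[nH]cc(-c4ccccc4)c3c2)cn1`, 20000 nM;
compound 3, `Cn1cc(-c2cnc3[nH]cc(-c4cccc(F)c4)c3c2)cn1`, 3000 nM.

All three numbers come from a physicochemical assay for solubility, read by LC-MS, in phosphate buffer, measured as thermodynamic solubility, with a stated time of 24 h, at pH 7.4; a lower number here means a less soluble compound, a higher number a more soluble compound. Compound 1 differs from compound 2 by cyano in place of hydrogen on an aromatic carbon, a change that gave a 10-fold lower number from compound 2 to compound 1 (1.00 log units; beyond the scatter). Compound 3 differs from compound 2 by fluoro in place of hydrogen on an aromatic carbon, which gave a 6.7-fold lower number from compound 2 to compound 3 (0.82 log units; beyond the scatter). Compound 4, `Cn1cc(-c2cnc3[nH]cc(-c4cc(F)cc(C#N)c4)c3c2)cn1`, is not yet measured; it differs from compound 3 by cyano in place of hydrogen on an aromatic carbon. This is the same kind of change as that from compound 2 to compound 1, though the place differs: in compound 1 the cyano sits para to a large group, whereas in compound 4 it sits meta to a fluoro group and meta to a large group. Because the earlier step was a 10-fold lower number from compound 2 to compound 1 (1.00 log units; beyond the scatter), compound 4 is expected to show a step of a 7.5-fold lower number from compound 3 to compound 4 (0.88 log units; beyond the scatter) in this assay, starting from compound 3. Compound 4 is therefore estimated at 400 nM, expected to lie between 150 nM and 1200 nM.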

Compound 4, solubility: 500 nM
For compound 4 the middle estimate is 1.3-fold (0.10 log units) below the measured one, within the range that was stated.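

In this assay the nitrile in place of hydrogen gave a 6.0-fold lower number from compound 3 to compound 4 (0.78 log units; beyond the scatter) and, on the core without fluoro, a 10-fold lower number from compound 2 to compound 1 (1.00 log units; beyond the scatter); both steps run the same way and lie beyond the scatter, so the change carried over between these two cores. This is a single pair of steps, however, and the nitrile sits elsewhere in compound 4 than in compound 1, meta to a fluoro group and meta to a large group, so it shows neither that place is irrelevant nor that the step holds on other cores. Nothing shown explains the drop.

The compounds shown leave open whether the step would persist with an amine or a carboxylic acid on the same ring. They also leave open how a nitrile at one fixed place would behave with and without the fluoro group.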